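Lactone to methylated aza-ring swap on a sulfonylazetidine amide

The source may hold more compounds than are shown below. What is called first, only, known or untested is meant among the compounds shown, and "the series" means these compounds.

Among the compounds with values here, compound 1 `O=C1OCc2cc(N(Cc3ccc(C4CCCCC4)cn3)C(=O)[C@H]3CCN3S(=O)(=O)c3c(F)c(F)c(F)c(F)c3F)ccc21` is the only member of this set with a number. In a functional assay on MCF7 cells (Homo sapiens) for antiproliferative activity, with a stated time of 72 h (on this read-out higher numbers stand for an effect only at larger amounts of compound and lower numbers for an effect already at smaller amounts), compound 1 gives 4600 nM. Compound 2 `CC(C)(C)c1ccc(CN(C(=O)[C@H]2CCN2S(=O)(=O)c2c(F)c(F)c(F)c(F)c2F)c2ccc(C(=O)NO)cc2F)cc1` was reported in this assay as "not determined" (no result reported), and compound 3 `O=C(NO)c1cc(F)c(N(Cc2ccc(C3CCOCC3)cc2)C(=O)[C@H]2CCN2S(=O)(=O)c2c(F)c(F)c(F)c(F)c2F)cc1O` likewise as "not determined" (no result reported), so neither offers a comparison. Compound 4 `Cn1ccc2cc(N(Cc3ccc(C4CCCCC4)cn3)C(=O)[C@H]3CCN3S(=O)(=O)c3c(F)c(F)c(F)c(F)c3F)ccc2c1=O` differs from compound 1 by a group of 12 heavy atoms (10 carbon, 1 nitrogen, 1 oxygen; one six-membered aromatic ring of carbon only, one six-membered aromatic ring with 1 hetero atom) in place of a group of 10 heavy atoms (8 carbon, 2 oxygen; one five-membered non-aromatic ring with 1 hetero atom, one six-membered aromatic ring of carbon only), on an amide-type nitrogen. Within the data shown here, no measured pair in this set shares that kind of change, so nothing here tells which way it moves this assay; the step is expected to stay within the usual scatter, with no clear direction. Compound 4 is therefore estimated at 3500 nM, within 1000 nM to 15000 nM, an expected step of a 1.3-fold lower number from compound 1 to compound 4 (0.12 log units; within the scatter).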

Compound 4, half-maximal effective concentration: 2800 nM
For compound 4 the middle estimate is 1.3-fold (0.10 log units) above the measured one; low and high end bracket the measured number.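

In this assay the step is a 1.6-fold lower number from compound 1 to compound 4 (0.22 log units; within the scatter), so at this amide-type nitrogen the larger group, with a nitrogen in one of its rings, is tolerated, and the two compounds cannot be told apart. Within the data shown here, this is the first comparison the set allows, and both groups carry the same count of hydrogen-bond donors and acceptors. Nothing available explains the result.

Going by these compounds, whether a group bearing a carboxylic acid or an amine at this place would move the number beyond the scatter stays open. Compound 2 and compound 3 still offer no comparison.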